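This account rests on a few compounds, and the source may have more. Where it says the series, first, only, none or still open, it means among the compounds named here.

Measured compounds in a functional assay on HCT-116 cells (Homo sapiens) for inhibition, read by sulforhodamine B assay, with a stated time of 72 h; a higher number here means a weaker inhibitor, a lower number a stronger inhibitor:
- compound 1, `CC(C)Cc1ccc(C(C)c2nnc3n2N=C(c2ccc(C(F)(F)F)cc2)CS3)cc1`: 6500 nM
- compound 2, `Cc1ccc(C2=Nn3c(nnc3C(C)c3ccc(CC(C)C)cc3)SC2)cc1`: 4000 nM
- compound 3, `CC(C)Cc1ccc(C(C)c2nnc3n2N=C(c2ccc([N+](=O)[O-])cc2)CS3)cc1`: "not active" (no number reported)

The three share one core and differ only in the group on an aromatic carbon of the six-membered aromatic ring of carbon only. Going by the values given here, compound 1 carries trifluoromethyl there and compound 2 carries methyl; the one computed step, a 1.6-fold lower number from compound 1 to compound 2 (0.21 log units; within the scatter), lies within the scatter, so the two values read as the same. Compound 3 carries nitro at that carbon and in this assay is reported as "not active" (no number reported), with no number attached, so compound 3 cannot be placed on the scale beside compounds 1 and 2 beyond being weaker than both.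

Compound 4, `COc1ccc(C2=Nn3c(nnc3C(C)c3ccc(CC(C)C)cc3)SC2)cc1`, differs from compound 3 by methoxy in place of nitro on an aromatic carbon. No measured step covers methoxy at this carbon, and no step starts from compound 3, so no size of change in this assay can be computed from the shown data. What the series does show is that trifluoromethyl and methyl at this carbon give near-identical, micromolar-range numbers, while nitro gives none; a methoxy analogue is expected to return a number rather than a blank, in the region of compounds 1 and 2. For compound 4 in this assay the expected value is 5000 nM, with a range of 2000 nM to 20000 nM.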

Compound 4, half-maximal inhibitory concentration: 4200 nM
Compound 4: the middle estimate sits 1.2-fold (0.08 log units) above what was measured; the measured number falls inside the stated range.
By their numbers in this assay, from the lowest: compounds 2, 4 and 1 (each within the scatter of the next).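

In this assay methoxy on this aromatic carbon, para to a large group, falls in with methyl and trifluoromethyl: a 1.1-fold higher number from compound 2 to compound 4 (0.02 log units; within the scatter) and a 1.5-fold lower number from compound 1 to compound 4 (0.19 log units; within the scatter) both lie within the scatter, so compounds 1, 2 and 4 read as the same. Going by these compounds alone, the earlier single step covered only two groups at this carbon, whereas three groups now give values that cannot be told apart, and among the four compounds only the nitro compound stands apart, with compound 3 reported as "not active" (no number reported) and without a place on the scale. The change 4-nitrophenyl to 4-methoxyphenyl therefore separates a blank from a micromolar-range number, but its size cannot be read from compound 3.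

Open, on these data alone, is whether nitro is alone in giving no number at this carbon, or whether an amine, a carboxylic acid or a nitrile there would also leave the assay without a value, and whether a longer alkoxy chain would stay with compounds 1, 2 and 4. Nothing available bears on why compound 3 differs from the other three.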